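This account rests on a few compounds, and the source may have more. Where it says the series, first, only, none or still open, it means among the compounds named here.

Compound 1, `CC[C@@H]1C(=O)N(C)c2cnc(-n3ccc4cc(F)ccc43)nc2N1C1CCCC1`, in an assay for inhibition of serine/threonine-protein kinase PLK2 (Homo sapiens), read by FRET and Z'-LYTE, with a stated time of 1 h (on this read-out higher numbers stand for weaker inhibition and lower numbers for stronger inhibition), gives 969 nM.
Compound 2, `CCC1C(=O)N(C)c2cnc(-n3ccc4cc(C(N)=O)ccc43)nc2N1c1ccn(C)n1`, in this assay gives 384 nM.
Compound 3, `CC[C@@H]1C(=O)N(C)c2cnc(-n3ccc4cc(C(=O)NC5CCCC5)ccc43)nc2N1C1CCCC1`, in this assay gives 7.06 nM.

Among these three numbers compound 2 stands second highest: compound 1 sits at a higher number and compound 3 at a far lower one, both gaps beyond the scatter. Compound 4, `CCC1C(=O)N(C)c2cnc(-n3ccc4cc(F)ccc43)nc2N1c1ccn(C)n1`, is the unmeasured partner of compound 2. The change is fluoro in place of carbamoyl on an aromatic carbon.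

Within the data shown here, only one measured step touches the same aromatic carbon: a 140-fold lower number from compound 1 to compound 3 (2.14 log units; beyond the scatter). That step ran in the opposite sense, installing a cyclopentylcarbamoyl where a fluoro had stood, and it was large. Compound 4 reverses the direction, taking a carbamoyl away and leaving a fluoro, so a higher number in this assay is expected for compound 4, though the amide removed here is the plain carbamoyl rather than the cyclopentyl one, so a smaller step than the measured one seems likely. Compound 4 is therefore estimated at 2500 nM, in a range from 800 nM to 8000 nM, which amounts to an expected step of a 6.5-fold higher number from compound 2 to compound 4 (0.81 log units; beyond the scatter).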

Compound 4, half-maximal inhibitory concentration: 1500 nM
Compound 4: middle estimate off by 1.7-fold (0.22 log units), on the high side, within the range that was stated.
By their numbers in this assay, from the lowest: compound 3; then compound 2; then compounds 1 and 4 (each within the scatter of the next).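

In this assay, the step of a 3.9-fold higher number from compound 2 to compound 4 (0.59 log units; beyond the scatter) shows that the plain carbamoyl, not only the cyclopentylcarbamoyl, gives a lower number than fluoro on this aromatic carbon. The earlier step, a 140-fold lower number from compound 1 to compound 3 (2.14 log units; beyond the scatter), could not show this, as its amide carried the cyclopentyl group. Both pairs now point the same way, with no compound shown going against it, although the new step is modest and the earlier one large.

The two pairs also differ in another place, so the compounds shown leave open how much of the larger step belongs to the cyclopentyl group. On these data alone, how an amine, a carboxylic acid or a nitrile would read on this aromatic carbon also remains open. No measurement is at hand that explains the step.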